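Triazole aryl swap at the assay limit: compound 3 to 4

The compounds below may be only part of what the source reports. "The series", "measured", "known", "first", "only" and "open" are said of these compounds alone.

Compound 3 `N#CC1=C(N)Oc2c(N)cc3nc4ccccc4nc3c2C12C(=O)N(Cc1cnnn1-c1cccc(Br)c1)c1ccccc12` is read in a functional assay on MCF7 cells (Homo sapiens) for antiproliferative activity, read by MTT assay, with a stated time of 48 h; on this read-out higher numbers stand for weaker inhibition and lower numbers for stronger inhibition. In this assay compound 3 gives only a limit, > 50000 nM. Compound 1 `CCOc1ccccc1-n1nncc1CN1C(=O)C2(C(C#N)=C(N)Oc3c2c2nc4ccccc4nc2c2ccccc32)c2ccccc21` likewise gives only a limit in this assay, > 50000 nM. Compound 2 `Cc1ccc(-n2nncc2CN2C(=O)C3(C(C#N)=C(N)Oc4c3c3nc5ccccc5nc3c3ccccc43)c3ccccc32)cc1C` also gives only a limit, > 50000 nM. Going by the values given here, the one measured step, a step that the two limits leave unreadable from compound 1 to compound 2, therefore cannot tell how large an aryl exchange on the aromatic nitrogen is. Compound 3 thus stands at the limit together with the other two; (the limit of > 50000 nM in this assay, at which 3 of the 3 values shown sit).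

Compound 4 `Cc1ccc(-n2nncc2CN2C(=O)C3(C(C#N)=C(N)Oc4c(N)cc5nc6ccccc6nc5c43)c3ccccc32)cc1Cl` differs from compound 3 by 3-chloro-4-methylphenyl in place of 3-bromophenyl on an aromatic nitrogen. Among the compounds with values here, no measured step gives a readable size for this kind of change; the only comparable step, from compound 1 to compound 2, is unreadable because both ends are limits. With all three values at the limit, the expected step that the limit leaves unreadable from compound 3 to compound 4 in this assay is no change beyond the scatter. Compound 4 is estimated at 70000 nM, within 20000 nM to 300000 nM, most probably reported again only as a limit.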

Compound 4, half-maximal inhibitory concentration: > 50000 nM
Compound 4 was reported as a limit; the forecaster's own chance of this, stated with the estimate: 85%; the middle value is on the limit's open side.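

Compound 3 and compound 4 are both reported only as limits, so the step between them cannot be read: the limit of > 50000 nM in this assay, at which 4 of the 4 values shown sit. The compounds shown leave open how far any aryl exchange on the aromatic nitrogen shifts antiproliferative activity, in either direction.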